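This account rests on a few compounds, and the source may have more. Where it says the series, first, only, none or still open, it means among the compounds named here.

Of the compounds shown here, three have been measured in a functional assay on A-431 cells (Homo sapiens) for inhibition, read by MTT assay, with a stated time of 72 h; on this read-out lower numbers stand for stronger inhibition of growth and higher numbers for weaker inhibition of growth.

Compound 1 `N#C/C(=C\c1ccc(Cl)cc1)C(=O)c1ccc[nH]1` gives 52000 nM in this assay.

Compound 2 `N#C/C(=C\c1ccc[nH]1)C(=O)NCc1ccc(Cl)c(Cl)c1` gives > 50000 nM in this assay, which is a limit of the assay rather than a number.

Compound 3 `COc1ccc(CNC(=O)/C(C#N)=C/c2ccco2)cc1` gives 16000 nM in this assay.

Of the two numbers recorded, compound 3 has the lower one; the nearest number, that of compound 1, sits higher by a gap that is beyond the scatter of repeated measurements. Compound 2 stops at the limit of > 50000 nM in this assay, at which 1 of the 3 values shown sits. None of these compounds differ from one another in a single place, so no measured step is available to judge the size a single change can bring.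

Compound 4 `COc1ccc(CNC(=O)/C(C#N)=C/c2cc(Br)co2)cc1` has not yet been measured. It differs from compound 3 in one spot: bromo in place of hydrogen on an aromatic carbon. Within the data shown here, with no comparable step among the measured compounds, only a modest shift is expected, in either direction and likely within or just beyond the scatter. The expected step is a 1.3-fold lower number from compound 3 to compound 4 (0.12 log units; within the scatter). For compound 4 the estimated value in this assay is 12000 nM, with a range from 4000 nM to 40000 nM.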

Compound 4, concentration for 50% growth inhibition: 14000 nM
Compound 4: the middle estimate sits 1.2-fold (0.07 log units) below what was measured; low and high end bracket the measured number.
By their numbers in this assay, from the lowest: compounds 4 and 3 (each within the scatter of the next); then compound 1.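

Among these compounds, this is the only measured step that changes one place alone, and in this assay it reads a 1.1-fold lower number from compound 3 to compound 4 (0.06 log units; within the scatter). It shows that on this five-membered aromatic ring with one oxygen, at the carbon two ring bonds from the ring oxygen, the change from furan-2-yl to 4-bromofuran-2-yl adds one heavy atom without moving the number beyond the scatter, so this position accepts bromo in place of hydrogen with no detectable change in growth inhibition. Nothing measured among these compounds bears on why the number holds.

On these data alone, whether an amine or a carboxylic acid on the same carbon would move the number beyond the scatter remains open. A single step also cannot show whether bromo would behave the same way on the other ring carbons.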